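Benzyl for phenyl on the piperazine nitrogen of compound 3

The compounds below may be only part of what the source reports. "The series", "measured", "known", "first", "only" and "open" are said of these compounds alone.

Measured compounds:
compound 1, `CN1CCN(CC(=O)Nc2ccc(-c3nc(-c4ccccc4)c(-c4ccccc4)n3C)cc2)CC1`: 49.1%
compound 2, `CCN1CCN(CC(=O)Nc2ccc(-c3nc(-c4ccccc4)c(-c4ccccc4)n3C)cc2)CC1`: 38.8%
compound 3, `Cn1c(-c2ccc(NC(=O)CN3CCN(c4ccccc4)CC3)cc2)nc(-c2ccccc2)c1-c1ccccc1`: 60.5%

Of the compounds shown here, three have been measured in a functional assay on HT-29 cells (Homo sapiens) for cytotoxicity, read by MTT assay, with a stated time of 24 h, tested at 32 ug/mL (on this read-out lower numbers stand for a weaker effect and higher numbers for a stronger effect at the one concentration tested), all sharing one core and differing only in the group on the amine nitrogen of the six-membered ring. Compound 3 stands highest of the three: compound 1 lies a number 11.4 percentage points higher from compound 1 to compound 3 (beyond the scatter) behind it, and compound 2 lies further back, a number 21.7 percentage points higher from compound 2 to compound 3 (beyond the scatter). Between the two smaller groups, the step of a number 10.3 percentage points lower from compound 1 to compound 2 (beyond the scatter) was also beyond the scatter.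

Compound 4, `Cn1c(-c2ccc(NC(=O)CN3CCN(Cc4ccccc4)CC3)cc2)nc(-c2ccccc2)c1-c1ccccc1`, carries the change (benzyl in place of phenyl on an amine nitrogen in a ring). Among the measured compounds shown here, no measured step covers this exact exchange. For the measured compounds named here, the steps that bear on it are those into compound 3: a number 11.4 percentage points higher from compound 1 to compound 3 (beyond the scatter) and a number 21.7 percentage points higher from compound 2 to compound 3 (beyond the scatter) both show the phenyl-bearing compound ahead of the compounds with a saturated group on that nitrogen, and a number 10.3 percentage points lower from compound 1 to compound 2 (beyond the scatter) shows that lengthening that saturated group lowered the read-out. Compound 4 has a saturated carbon on the nitrogen again, so a modest downward step is expected, though it could fall within the scatter.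

Compound 4 is therefore estimated at 50%, with a range from 32% to 68%. This estimate means a step of a number 10.5 percentage points lower from compound 3 to compound 4 (beyond the scatter), which is expected to be downward and modest.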

Compound 4, a percentage reported as activity, at one concentration (the size of the read-out at that concentration, not a potency): 40%
Estimate against measurement, compound 4: 10 percentage points above; measured number inside the range.
By their numbers in this assay, from the lowest: compounds 2, 4 and 1 (each within the scatter of the next, the first and the last beyond it); then compound 3.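

In this assay, benzyl in place of phenyl on the amine nitrogen in a ring keeps the six-membered aromatic ring but still gives a number 20.5 percentage points lower from compound 3 to compound 4 (beyond the scatter), so the presence of that aromatic ring alone does not secure the high read-out of compound 3. The benzyl compound also falls in with the compounds carrying the small saturated groups, with a number 1.2 percentage points higher from compound 2 to compound 4 (within the scatter) and a number 9.1 percentage points lower from compound 1 to compound 4 (within the scatter), which leaves phenyl as the only group shown here that stands clear of the others. No information is available on what lies behind this difference.

Going by these compounds, it remains open whether a phenethyl group, with its longer chain to the same aromatic ring, would stay with the benzyl compound, and whether a pyridine ring or a fluorine on the phenyl ring would hold the read-out of compound 3. With only one concentration and one cell line shown, it is also open whether these steps would persist as stronger or weaker effects at other concentrations or appear in other cell lines.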